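Chloro to Iodo Exchange and Solubility in Two Related Cores

A few compounds are considered here, and "the series" means these few. Any claim that something is new, unique, unknown or untested is made for them only; others in the source may bear on it.

Measured so far:
Compound 1 `CCc1ccc(-c2nc3c(c(C)nn3-c3ccccc3)c(-c3ccccc3I)c2C#N)cc1`: 8500 nM
Compound 2 `CCc1ccc(-c2nc3c(c(C)nn3-c3ccccc3)c(-c3ccccc3Cl)c2C#N)cc1`: 1700 nM
Compound 3 `Cc1nn(-c2ccccc2)c2nc(-c3ccc(Cl)cc3)c(C#N)c(-c3ccccc3O)c12`: 3800 nM

These three compounds were measured in a physicochemical assay for solubility, read by spectrophotometry, in phosphate buffer, with a stated time of 18 h, at pH 7.4; a lower number here means a less soluble compound, a higher number a more soluble compound. Compound 1 and compound 2 share one core and differ only by iodo in place of chloro on an aromatic carbon; that change gave a 5.0-fold higher number from compound 2 to compound 1 (0.70 log units; beyond the scatter). Compound 3 carries a different core, and how its core differs from that of compound 2 is not broken down here. The unmeasured compound 4 `Cc1nn(-c2ccccc2)c2nc(-c3ccc(I)cc3)c(C#N)c(-c3ccccc3O)c12` is built from compound 3 by iodo in place of chloro on an aromatic carbon. This is the same kind of change as that from compound 2 to compound 1, but not the same: in the earlier pair the exchanged halogen sits ortho to a large group, while in compound 4 it sits para to a large group. Within the data shown here, because the single earlier example of this change gave a 5.0-fold higher number from compound 2 to compound 1 (0.70 log units; beyond the scatter), a rise is expected in this assay for compound 4 as well, but with a different surrounding it is estimated to be smaller, around a 2.5-fold higher number from compound 3 to compound 4 (0.40 log units; beyond the scatter). Compound 4 is therefore expected to give about 9500 nM, plausibly between 3000 nM and 30000 nM.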

Compound 4, solubility: 1500 nM
For compound 4 the middle estimate is 6.3-fold (0.80 log units) above the measured one; measured number below the stated range.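

In this assay the exchange of chloro for iodo gave a 5.0-fold higher number from compound 2 to compound 1 (0.70 log units; beyond the scatter) in one core, but a 2.5-fold lower number from compound 3 to compound 4 (0.40 log units; beyond the scatter) in the other. Both steps lie beyond the usual scatter and run in opposite directions, which shows that the direction of this change did not carry over from one core to the other, although two pairs cannot establish a general rule for the series. The core is also not the only difference, as the exchanged halogen in compound 4 is para to a large group and the site differs in the earlier pair, and no measurement at hand explains the reversal or separates the contribution of core from that of site.

As far as these compounds go, it remains open how chloro and iodo would compare at one matched site on both cores, which would help separate those two contributions. From the compounds shown here alone, it is also open whether bromo, or an amine, at the site of the exchange would follow either step.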